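Adding one carbon to a bromo ester

A few compounds are considered here, and "the series" means these few. Any claim that something is new, unique, unknown or untested is made for them only; others in the source may bear on it.

Compound 1 `CCOC(=O)CC1CNC(=O)c2cc(Br)c(Br)n21`: 41000 nM
Compound 2 `COC(=O)CC1CNC(=O)c2ccc(Br)n21`: 65000 nM

In a functional assay on A549 cells (Homo sapiens) for cytotoxicity, read by CCK-8 assay, with a stated time of 72 h (on this read-out higher numbers stand for weaker inhibition and lower numbers for stronger inhibition), compound 2 gives 65000 nM, and compound 1 gives 41000 nM. These two values lie within the usual scatter of each other, and compound 2 cannot be ranked apart from compound 1.

Compound 3 `CCOC(=O)CC1CNC(=O)c2ccc(Br)n21` has not yet been measured. It differs from compound 2 by a single change: methyl in place of hydrogen on a saturated chain carbon bound to an oxygen next to a carbonyl group. This places methyl in place of hydrogen on a saturated chain carbon bound to an oxygen next to a carbonyl group, and methoxycarbonyl becomes ethoxycarbonyl. Going by the values given here, no measured pair shows this change alone. A step beyond the scatter is not expected in this assay, in either direction. The estimated 1.2-fold lower number from compound 2 to compound 3 (0.07 log units; within the scatter) is small. Compound 3 is expected at 55000 nM, within an estimated range of 25000 nM to 110000 nM.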

Compound 3, half-maximal inhibitory concentration: 32000 nM
Compound 3: the middle estimate sits 1.7-fold (0.24 log units) above what was measured, within the range that was stated.
By their numbers in this assay, from the lowest: compounds 3, 1 and 2 (each within the scatter of the next, the first and the last beyond it).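

In this assay, going by these compounds alone, lengthening methoxycarbonyl to ethoxycarbonyl gives a 2.0-fold lower number from compound 2 to compound 3 (0.31 log units; beyond the scatter), a modest change, but the first single change in this small set that stands beyond the usual scatter. Swapping a bromo for hydrogen on an aromatic carbon, with the ethoxycarbonyl group kept in place, gives a 1.3-fold lower number from compound 1 to compound 3 (0.11 log units; within the scatter), so that pair cannot be ranked apart and this step shows no readable effect of that bromo. Nothing available explains the difference between methoxycarbonyl and ethoxycarbonyl.

As far as these compounds go, it remains open whether a longer chain such as propoxycarbonyl would continue the trend, or whether a carboxylic acid or an amide in place of the ester would keep it. From the compounds shown here alone, it is also open whether the same added methyl gives a similar step when the extra bromo is present.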